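Working notes: a second fluoro on the core of compound 1

The compounds below may be only part of what the source reports. "The series", "measured", "known", "first", "only" and "open" are said of these compounds alone.

Compound 1 `O=C(O)c1cnc2c(F)cccc2c1` gives only a limit in a functional assay on the whole organism (strain Sprague-Dawley) for inhibition, with Rattus norvegicus as the target; on this read-out higher numbers stand for an effect only at larger amounts of compound and lower numbers for an effect already at smaller amounts: its value > 25 mg/kg is a limit of the assay, not a number. Compound 2 `COc1cccc2cc(C(=O)O)cnc12` gives 25 mg/kg in this assay. Compound 3 `CCc1cccc2cc(C(=O)O)cnc12` gives > 50 mg/kg in this assay, again a limit. The measured steps all replace the fluoro of compound 1: a number no higher from compound 1 to compound 2 (the limit leaves the size open), a step that the two limits leave unreadable from compound 1 to compound 3 and an at least 2.0-fold higher number from compound 2 to compound 3 (0.30 log units; that floor lies within the scatter). Compound 4 `O=C(O)c1cnc2c(F)cc(F)cc2c1` differs from compound 1 thus: fluoro in place of hydrogen on an aromatic carbon. For the measured compounds named here, no measured step keeps the fluoro and adds a second group to the shared core, so none bears directly on this change, and no step beyond the scatter is expected in this assay in either direction. Accordingly a small step is expected: a step that the limit leaves unreadable from compound 1 to compound 4. For compound 4 the estimate is 40 mg/kg, with a range of 15 mg/kg to 100 mg/kg.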

Compound 4, minimum effective dose: 25 mg/kg
Compound 4: middle estimate off by 1.6-fold (0.20 log units), on the high side, and the stated range covers the measured number.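

In this assay, fluoro in place of hydrogen on an aromatic carbon, meta to a fluoro group, gives a number no higher from compound 1 to compound 4 (the limit leaves the size open). This is the first step shown that keeps the fluoro of compound 1 and changes another place on the shared core. Compound 1 gives > 25 mg/kg, a limit of the assay and not a number, so the size of the step stays unreadable: the limit of > 25 mg/kg in this assay, at which 1 of the 4 values shown sits.

As far as these compounds go, whether this fluoro gives the same result without the first fluoro stays open. So does how an amine or a nitrile on the same carbon would compare with compound 4.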